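Methylsulfanyl for Methyl on a Benzimidazole Piperidine

This account rests on a few compounds, and the source may have more. Where it says the series, first, only, none or still open, it means among the compounds named here.

Measured compounds:
- compound 1, `O=C(CCCN1CCC(n2c(Sc3ccccc3[N+](=O)[O-])nc3ccccc32)CC1)c1ccc(F)cc1`, 11 mg/kg
- compound 2, `Cc1nc2ccccc2n1C1CCN(CCCC(c2ccc(F)cc2)c2ccc(F)cc2)CC1`, 40 mg/kg

Both compounds were tested in a functional assay on the whole organism (strain STD-ddY) for inhibition, with Mus musculus as the target, with a stated time of 5 min; on this read-out lower numbers stand for an effect already at smaller amounts and higher numbers for an effect only at larger amounts of compound. Compound 1 gives 11 mg/kg, while compound 2 gives 40 mg/kg. Of the two numbers, compound 2 holds the higher one, and its distance from compound 1 lies beyond the usual scatter of repeated measurements, so compound 2 needs the larger amount for the same effect in this assay.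

Compound 3, `CSc1nc2ccccc2n1C1CCN(CCCC(c2ccc(F)cc2)c2ccc(F)cc2)CC1`, has not yet been measured. It differs from compound 2 in one place: methylsulfanyl in place of methyl on an aromatic carbon. The methyl on the aromatic carbon between two ring nitrogen atoms is replaced by methylsulfanyl, which brings in one sulfur and one hydrogen-bond acceptor where none stood before.

Within the data shown here, no measured pair shows what this exact change does. On the two values known, a small step is expected, in either direction, and most likely not beyond the scatter: the step of a 1.3-fold lower number from compound 2 to compound 3 (0.12 log units; within the scatter) is the estimate. Compound 3 is therefore expected to give about 30 mg/kg, with a range from 12 mg/kg to 80 mg/kg in this assay.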

Compound 3, dose for half-maximal effect: 13 mg/kg
Beside the measured number, compound 3's estimate is 2.3-fold (0.36 log units) above it; the range from low to high includes it.
By their numbers in this assay, from the lowest: compounds 1 and 3 (each within the scatter of the next); then compound 2.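

In this assay, the aromatic carbon between two ring nitrogen atoms proves sensitive to a small edit: replacing methyl with methylsulfanyl gives a 3.1-fold lower number from compound 2 to compound 3 (0.49 log units; beyond the scatter), while the rest of the molecule stays the same. Among these compounds, this is the first direct reading of this position, as compound 1 and compound 2 differ in more than one place and so could not isolate the effect of this group. Nothing available here explains the step, so it cannot be assigned to the added sulfur, the added hydrogen-bond acceptor or the extra heavy atom.

The compounds shown leave open how other groups would read at this position, such as methoxy, which has oxygen where methylsulfanyl has sulfur, or ethylsulfanyl, which has a longer chain. They also leave open whether the same swap would give a similar step in a compound carrying the fluorophenyl ketone chain of compound 1 rather than the bis(fluorophenyl)butyl chain shared by compound 2 and compound 3.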